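The compounds below may be only part of what the source reports. "The series", "measured", "known", "first", "only" and "open" are said of these compounds alone.

Compound 2 `ClCc1ccccc1Cn1cnc2c(Cl)nc(Cl)nc21` and compound 1 `ClCc1ccc(Cn2cnc3c(Cl)ncnc32)cc1` share a core and differ in where the chloromethyl group sits on the benzyl ring and in the second chloro group on the core of compound 2. In a functional assay on HCC 2998 cells (Homo sapiens) for cytotoxicity, read by sulforhodamine B assay, with a stated time of 48 h (on this read-out higher numbers stand for weaker inhibition of growth and lower numbers for stronger inhibition of growth), compound 2 gives 3380 nM, the higher of the two numbers recorded, while compound 1 gives 2040 nM; the two values lie within the usual scatter of each other. Compound 3 `ClCc1ccccc1Cn1cnc2c(Cl)ncnc21` is reached from compound 2 by the change (hydrogen in place of chloro on an aromatic carbon). Among the compounds with values here, no measured pair shows this change directly, and the comparison of compound 2 with compound 1 is confounded by the moved chloromethyl group. The step is therefore expected to be small, a 1.3-fold lower number from compound 2 to compound 3 (0.11 log units; within the scatter), with no clear direction beyond the scatter. Compound 3 is accordingly estimated at 2600 nM in this assay, with a likely range from 1000 nM to 7000 nM.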

Compound 3, concentration for total growth inhibition: 3540 nM
Beside the measured number, compound 3's estimate is 1.4-fold (0.13 log units) below it, within the range that was stated.
By their numbers in this assay, from the lowest: compounds 1, 2 and 3 (each within the scatter of the next).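

Within the data shown here, compound 2 and compound 3 form the first pair that isolates this change: in this assay, hydrogen in place of chloro on an aromatic carbon between two ring nitrogen atoms gives a 1.0-fold higher number from compound 2 to compound 3 (0.02 log units; within the scatter). Among these compounds, no earlier pair differed in this one place, so the result shows for the first time that this chloro group can be exchanged for hydrogen while the two numbers stay within the scatter of each other. No measurement at hand offers an explanation for this outcome.

The compounds shown leave open whether an amine or a methoxy group at this same position would shift the number beyond the scatter. They also leave open whether the same exchange would give a similar step with the chloromethyl group placed as in compound 1.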